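Swapping the Aryl Group on a Weak Amide Series

This account rests on a few compounds, and the source may have more. Where it says the series, first, only, none or still open, it means among the compounds named here.

Among the compounds with values here, in a functional assay on A549 cells (Homo sapiens) for antiproliferative activity, read by MTT assay, with a stated time of 72 h (on this read-out higher numbers stand for weaker inhibition and lower numbers for stronger inhibition), compound 2 `O=C(Nc1ccc(Cl)c(-c2nnc3c(Cl)cccn23)c1)c1cccc(Cl)c1` gives 52700 nM, the only real number measured so far. Compound 1 `Cc1nc(C(=O)Nc2ccc(Cl)c(-c3nnc4c(Cl)cccn34)c2)cs1` instead sits at the limit of > 100000 nM in this assay, at which 1 of the 2 values shown sits, reported as > 100000 nM rather than as a number. Within the data shown here, the step of an at least 1.8-fold lower number from compound 1 to compound 2 (0.27 log units; that floor lies within the scatter) is the one measured change at the carbonyl carbon, and its floor tells little about direction. Compound 3 `CS(=O)(=O)c1ccc(C(=O)Nc2ccc(Cl)c(-c3nnc4c(Cl)cccn34)c2)cc1` differs from compound 2 by 4-(methylsulfonyl)phenyl in place of 3-chlorophenyl on a carbonyl carbon. Among the measured compounds shown here, with only that step to go by, the expected change is a 1.1-fold higher number from compound 2 to compound 3 (0.06 log units; within the scatter), nothing clearly beyond the scatter. Compound 3 is therefore estimated at 60000 nM, within 15000 nM to 200000 nM.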

Compound 3, half-maximal inhibitory concentration: > 100000 nM
Compound 3: only a limit was reported (the forecaster's own chance of this, stated with the estimate: 40%); at least 1.6-fold (0.22 log units) between middle value and limit.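

Compound 3 gives > 100000 nM in this assay, which is a limit and not a number. The change to 4-(methylsulfonyl)phenyl on the carbonyl carbon gives an at least 1.8-fold higher number from compound 2 to compound 3 (0.27 log units; that floor lies within the scatter), so it fixes no direction, and the step between the two compounds at the limit cannot be read. A second aryl group on this carbonyl carbon now ends at the same limit: the limit of > 100000 nM in this assay, at which 2 of the 3 values shown sit.

As far as these compounds go, it remains open whether any group here can give a number clearly lower than that of compound 2. A small amine or a carboxylic acid on the phenyl ring, or a plain alkyl chain in place of the ring, could test this.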